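Replacing the dichlorophenyl with a naphthyl group

The source may report more compounds than this note shows. Statements on the series, on what has been measured and on what is new or still open speak of the compounds shown alone.

Measured compounds:
compound 1, `COc1ccc(-n2nc(Sc3ccc(Cl)cc3)cc(CC[C@@H](C)NC(=O)[C@H]3CNCC[C@@H]3c3ccc(Cl)cc3Cl)c2=O)cc1`: 3.2 nM
compound 2, `COc1ccc(-n2nc(Sc3ccc(Cl)cc3)cc(CC[C@@H](C)NC(=O)[C@H]3CNCC[C@@H]3c3cccc(F)c3)c2=O)cc1`: 490 nM
compound 3, `COc1ccc(-n2nc(Sc3ccc(Cl)cc3)cc(CC[C@@H](C)NC(=O)[C@H]3CNCC[C@@H]3c3ccccc3F)c2=O)cc1`: 13 nM

In an assay on CHO cells for binding affinity to Melanocortin receptor 4 (Homo sapiens) (a higher number here means a weaker inhibitor, a lower number a stronger inhibitor), compound 1 gives the lowest number of the three. Each replacement of its 2,4-dichlorophenyl on a saturated ring carbon weakened binding, though by very different amounts: a 4.1-fold higher number from compound 1 to compound 3 (0.61 log units; beyond the scatter), whereas a 150-fold higher number from compound 1 to compound 2 (2.19 log units; beyond the scatter). Between the two fluorophenyl compounds, a 38-fold lower number from compound 2 to compound 3 (1.58 log units; beyond the scatter).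

Compound 4, `COc1ccc(-n2nc(Sc3ccc(Cl)cc3)cc(CC[C@@H](C)NC(=O)[C@H]3CNCC[C@@H]3c3cccc4ccccc34)c2=O)cc1`, has not been measured. It differs from compound 1 as follows: naphthalen-1-yl in place of 2,4-dichlorophenyl on a saturated ring carbon. Both measured steps away from the 2,4-dichlorophenyl bear on this change, and both raised the number in this assay, one modestly and one greatly. Compound 4 is therefore expected to bind more weakly than compound 1, most likely by a modest to large step, a 9.4-fold higher number from compound 1 to compound 4 (0.97 log units; beyond the scatter). The estimate for compound 4 in this assay is 30 nM, within a range of 5 nM to 250 nM.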

Compound 4, half-maximal inhibitory concentration: 89 nM
The estimate for compound 4 lay 3.0-fold (0.47 log units) below the measured number; low and high end bracket the measured number.
By their numbers in this assay, from the lowest: compound 1; then compound 3; then compound 4; then compound 2.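

Naphthalen-1-yl, the only group here without a halogen, retains binding in this assay but loses much of the strength seen with 2,4-dichlorophenyl (a 28-fold higher number from compound 1 to compound 4 (1.44 log units; beyond the scatter)). It also falls short of 2-fluorophenyl (a 6.8-fold higher number from compound 3 to compound 4 (0.84 log units; beyond the scatter)) yet improves on 3-fluorophenyl (a 5.5-fold lower number from compound 2 to compound 4 (0.74 log units; beyond the scatter)), so two aromatic rings at this saturated ring carbon give a result within the range of the halogenated phenyl groups, not beyond it. Nothing available explains this order. The compounds shown leave open how naphthalen-2-yl, 2-chlorophenyl or 4-chlorophenyl would compare, so the separate contribution of each chlorine in compound 1 remains unknown.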